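Bromoindole imidazoles: swapping the benzylic substituent

The source may report more compounds than this note shows. Statements on the series, on what has been measured and on what is new or still open speak of the compounds shown alone.

compound 1 `Brc1ccc2[nH]c(-c3cncn3Cc3ccccc3)cc2c1` gives 11000 nM in an assay on HEK293 cells for inhibition of Indoleamine 2,3-dioxygenase 1 (Homo sapiens), with a stated time of 30 min; a lower number here means that less compound is needed, a higher number that more compound is needed for the effect
compound 2 `Cc1ccc(Cn2cncc2-c2cc3cc(Br)ccc3[nH]2)cc1` gives 4290 nM in this assay
compound 3 `Brc1ccc2[nH]c(-c3cncn3CC3CCCCN3)cc2c1` gives 10700 nM in this assay

Compound 3 stands second highest of the three numbers; its number and that of compound 1 lie within the scatter of each other, while compound 2 sits beyond it, a 2.5-fold higher number from compound 2 to compound 3 (0.40 log units; beyond the scatter). Compound 4 `Oc1ccccc1Cn1cncc1-c1cc2cc(Br)ccc2[nH]1` differs from compound 3 by 2-hydroxyphenyl in place of piperidin-2-yl on a saturated chain carbon bound to an aromatic nitrogen. Within the data shown here, two measured steps bear on this change. Replacing the benzyl group's phenyl by the saturated ring gave a 1.0-fold lower number from compound 1 to compound 3 (0.01 log units; within the scatter), and the methyl-bearing aromatic ring gave a 2.6-fold lower number from compound 1 to compound 2 (0.41 log units; beyond the scatter). Compound 4 brings an aromatic ring back, so a step of a 1.3-fold lower number from compound 3 to compound 4 (0.13 log units; within the scatter) in this assay is expected, at most modest and possibly within the scatter. Compound 4 is therefore estimated at 8000 nM, with a range of 3000 nM to 25000 nM.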

Compound 4, half-maximal effective concentration: 5010 nM
Beside the measured number, compound 4's estimate is 1.6-fold (0.20 log units) above it; the measured number falls inside the stated range.
By their numbers in this assay, from the lowest: compounds 2 and 4 (each within the scatter of the next); then compounds 3 and 1 (each within the scatter of the next).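

With a 2.2-fold lower number from compound 1 to compound 4 (0.34 log units; beyond the scatter) in this assay, adding a hydroxy group joins the methyl of compound 2 as a second substitution on the phenyl ring that moves the number beyond the scatter. The two substituted rings are not separated, with a 1.2-fold higher number from compound 2 to compound 4 (0.07 log units; within the scatter) in this comparison. Against piperidin-2-yl, 2-hydroxyphenyl gives a 2.1-fold lower number from compound 3 to compound 4 (0.33 log units; beyond the scatter) here, a separation the unsubstituted phenyl of compound 1 did not show.

From the compounds shown here alone, whether an amine or a carboxylic acid on this ring would give a similar step remains open. Nothing at hand explains these steps.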